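The compounds below may be only part of what the source reports. "The series", "measured", "known", "first", "only" and "open" are said of these compounds alone.

Compounds measured in an assay on cells for binding affinity to Cyclin-C/Cyclin-dependent kinase 19 (Homo sapiens), read by LanthaScreen; on this read-out higher numbers stand for weaker inhibition and lower numbers for stronger inhibition:
compound 1 `Cn1ncc2cc(-c3cnc4[nH]ncc4c3N3CCC4(CCNC4=O)CC3)ccc21` gives 214 nM
compound 2 `O=C1NCCC12CCN(c1c(-c3ccc4scnc4c3)cnc3[nH]ccc13)CC2` gives 14 nM
compound 3 `Cn1cnc2ccc(-c3cnc4[nH]ccc4c3N3CCC4(CCNC4=O)CC3)cc21` gives 11 nM

Compound 2 stands second highest of the three numbers; compound 3 lies closest to it, within the scatter, while compound 1 is furthest, with a higher number. Compound 4 `O=C1NCCC12CCN(c1c(-c3ccn4ccnc4c3)cnc3[nH]ccc13)CC2` differs from compound 2 in one place: a group of 9 heavy atoms (7 carbon, 2 nitrogen; one five-membered aromatic ring with 2 hetero atoms, one six-membered aromatic ring with 1 hetero atom) in place of a group of 9 heavy atoms (7 carbon, 1 nitrogen, 1 sulfur; one five-membered aromatic ring with 2 hetero atoms, one six-membered aromatic ring of carbon only), on an aromatic carbon. For the measured compounds named here, one measured step bears on this change: a 1.3-fold lower number from compound 2 to compound 3 (0.10 log units; within the scatter), where one bicyclic aromatic group replaced another on an aromatic carbon and the number stayed within the scatter. Compound 1 differs from compound 2 in two places, so its value gives no single-step guidance. On this basis compound 4 is expected to stay close to compound 2, with the step of a 1.4-fold higher number from compound 2 to compound 4 (0.15 log units; within the scatter) expected to fall within the scatter. The estimate for compound 4 in this assay is 20 nM, with a range from 7 nM to 60 nM.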

Compound 4, half-maximal inhibitory concentration: 68 nM
Compound 4: middle estimate off by 3.4-fold (0.53 log units), on the low side; measured number outside the range, above it.
By their numbers in this assay, from the lowest: compounds 3 and 2 (each within the scatter of the next); then compound 4; then compound 1.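

In this assay, exchanging one bicyclic aromatic group for another on this aromatic carbon is not always neutral: the change gives a 4.9-fold higher number from compound 2 to compound 4 (0.69 log units; beyond the scatter) and also a 6.2-fold higher number from compound 3 to compound 4 (0.79 log units; beyond the scatter) while the earlier exchange gave a 1.3-fold lower number from compound 2 to compound 3 (0.10 log units; within the scatter) and stayed within the scatter. Among these three compounds, only compound 4 carries a hetero atom in the six-membered aromatic ring of this group, and it alone stands apart. Nothing measured here explains this gap. From the compounds shown here alone, whether a simple phenyl or a pyridin-4-yl group would hold the values of compound 2 and compound 3 remains open.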